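Cytotoxicity outlook for the carboxyethenyl analogue of compound 2

This account rests on a few compounds, and the source may have more. Where it says the series, first, only, none or still open, it means among the compounds named here.

In an ADME assay on HEp-2 cells (Homo sapiens) for cytotoxicity, read by CCK-8 assay, with a stated time of 6 days (a lower number here means that less compound is tolerated, a higher number that more compound is tolerated), compound 1 `O=c1n(Cc2nc3cc(Cl)ccn3c2CO)c2cnccc2n1C1CC1` gives only a limit, > 100000 nM. Compound 2 `CS(=O)(=O)CCNC(=O)c1c(Cn2c(=O)n(C3CC3)c3ccncc32)nc2cc(Cl)ccn12` likewise gives only a limit in this assay, > 100000 nM. The step that the two limits leave unreadable from compound 1 to compound 2 therefore cannot be sized. Compound 3 `O=C(O)/C=C/c1c(Cn2c(=O)n(C3CC3)c3ccncc32)nc2cc(Cl)ccn12` differs from compound 2 by 2-carboxyethenyl in place of (2-(methylsulfonyl)ethyl)carbamoyl on an aromatic carbon. Among the measured compounds shown here, no measured step bears on this change; both values shown sit at the limit of > 100000 nM in this assay, at which 2 of the 2 values shown sit, so no direction or size of step in this assay can be read from them. Compound 3 is expected to stay at the same limit, estimated at 100000 nM (range 50000 nM to 200000 nM), the expected step being a number no higher from compound 2 to compound 3 (the limit leaves the size open).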

Compound 3, half-maximal cytotoxic concentration: > 100000 nM
Compound 3 ended at the assay's limit; the forecaster's own chance of this, stated with the estimate: 80%; the middle value sits exactly at the limit.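

No step among compound 1, compound 2 and compound 3 can be read, as all three values are limits: the limit of > 100000 nM in this assay, at which 3 of the 3 values shown sit.

The compounds shown leave open where their half-maximal cytotoxic concentrations lie and whether these changes on the aromatic carbon shift them.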